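The source may hold more compounds than are shown below. What is called first, only, known or untested is meant among the compounds shown, and "the series" means these compounds.

Measured so far:
compound 1 `COc1cc2c(Oc3ccc(NC(=O)c4nccc(-c5ccc(F)cc5)n4)cc3F)ccnc2cc1OCCCN1CCN(C)CC1` gives 42 nM in a functional assay on HT-29 cells (Homo sapiens) for cytotoxicity, read by MTT assay, with a stated time of 72 h; on this read-out higher numbers stand for weaker inhibition and lower numbers for stronger inhibition;
compound 2 `COc1cc2c(Oc3ccc(NC(=O)c4nccc(-c5ccccc5)n4)cc3F)ccnc2cc1OCCCN1CCCC1` gives 390 nM in this assay.

On these two numbers compound 2 stands highest; its nearest neighbour, compound 1, gives a number below it by more than the scatter, but the two differ in two places at once, so that gap cannot be assigned to either change. Compound 3 `COc1cc2c(Oc3ccc(NC(=O)c4nccc(-c5ccc(F)cc5)n4)cc3F)ccnc2cc1OCCCN1CCCC1` arises from compound 2 by fluoro in place of hydrogen on an aromatic carbon. Within the data shown here, no step between measured compounds covers this change alone. A modest decrease of the number is expected, because compound 1 carrying the same fluoro gives 42 nM. The expected step is a 2.4-fold lower number from compound 2 to compound 3 (0.39 log units; beyond the scatter). Compound 3 is therefore estimated at 160 nM, between 50 nM and 500 nM.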

Compound 3, half-maximal inhibitory concentration: 160 nM
For compound 3 middle estimate and measured number coincide at the digits printed; the measured number falls inside the stated range.
By their numbers in this assay, from the lowest: compound 1; then compound 3; then compound 2.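

In this assay the change from phenyl to 4-fluorophenyl now has a step of its own, a 2.4-fold lower number from compound 2 to compound 3 (0.39 log units; beyond the scatter), with the pyrrolidin-1-yl end of the chain held fixed. The chain end also has its own step, as pyrrolidin-1-yl in place of 4-methylpiperazin-1-yl gives a 3.8-fold higher number from compound 1 to compound 3 (0.58 log units; beyond the scatter), with the 4-fluorophenyl held fixed. Nothing available explains either step. On these data alone, whether chloro or methoxy in place of this fluoro would shift the number remains open. So does the effect of morpholin-4-yl at the chain end.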